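Ring closure on the amide aryl group and its solubility

A few compounds are considered here, and "the series" means these few. Any claim that something is new, unique, unknown or untested is made for them only; others in the source may bear on it.

Measured so far:
Compound 1 `CCCc1ccc(NC(=O)COc2cc(C)nc3ccc(OC)cc23)cc1` gives 3900 nM.
Compound 2 `CCc1ccc(NC(=O)COc2cc(C)nc3ccc(OC)cc23)cc1` gives 5200 nM.
Compound 3 `COc1ccc2nc(C)cc(OCC(=O)Nc3ccc(C)c(C)c3)c2c1` gives 10400 nM.

In a physicochemical assay for solubility, measured as kinetic solubility, at pH 5.8 (a higher number here means a more soluble compound, a lower number a less soluble compound), compound 1 stands lowest of the three numbers; its nearest neighbour is compound 2 with a 1.3-fold higher number from compound 1 to compound 2 (0.12 log units; within the scatter), and its furthest is compound 3 with a 2.7-fold higher number from compound 1 to compound 3 (0.43 log units; beyond the scatter). The step from compound 2 to compound 3 is a 2.0-fold higher number from compound 2 to compound 3 (0.30 log units; within the scatter).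

Compound 4 `COc1ccc2nc(C)cc(OCC(=O)Nc3ccc4c(c3)CCC4)c2c1` has not been measured. It differs from compound 1 in this way: 2,3-dihydro-1H-inden-5-yl in place of 4-propylphenyl on an amide-type nitrogen.

For the measured compounds named here, two measured steps bear on this change, since both also replace the group on the amide-type nitrogen while keeping the shared core: a 2.7-fold higher number from compound 1 to compound 3 (0.43 log units; beyond the scatter) and a 2.0-fold higher number from compound 2 to compound 3 (0.30 log units; within the scatter). Both run upward, one modestly beyond the scatter, one within it. Going by the values given here, compound 4 keeps the same count of heavy atoms as compound 1 but closes them into a second ring, a change no measured pair shows directly, so the expected step is small and uncertain.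

Compound 4 is therefore expected to give about 4500 nM, in a range from 2000 nM to 10000 nM. This estimate corresponds to an expected step of a 1.2-fold higher number from compound 1 to compound 4 (0.06 log units; within the scatter), which is within the scatter.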

Compound 4, solubility: 2800 nM
Compound 4: the middle estimate sits 1.6-fold (0.21 log units) above what was measured; measured number inside the range.
By their numbers in this assay, from the lowest: compounds 4, 1, 2 and 3 (each within the scatter of the next, the first and the last beyond it).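

In this assay, the 2,3-dihydro-1H-inden-5-yl group on the amide-type nitrogen does not match 3,4-dimethylphenyl, with a 3.7-fold lower number from compound 3 to compound 4 (0.57 log units; beyond the scatter). Against the two open-chain groups it cannot be separated, with a 1.4-fold lower number from compound 1 to compound 4 (0.14 log units; within the scatter) and a 1.9-fold lower number from compound 2 to compound 4 (0.27 log units; within the scatter). The higher number of compound 3 therefore did not carry over to compound 4, and closing the five-membered non-aromatic ring gave no measurable gain over 4-propylphenyl or 4-ethylphenyl.

Nothing at hand explains these differences. Going by these compounds, whether an aryl group carrying an amine or a carboxylic acid in place of these groups on the amide-type nitrogen would give a clearly different number stays open, and these compounds do not settle it.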